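The compounds below may be only part of what the source reports. "The series", "measured", "known", "first", "only" and "open" are said of these compounds alone.

Measured so far in a functional assay on MCF7 cells (Homo sapiens) for inhibition, read by sulforhodamine B assay, with a stated time of 48 h; a higher number here means a weaker inhibitor of growth, a lower number a stronger inhibitor of growth:

compound 1 `CC(C)(C)c1ccc(NC2=NCCO2)cc1`: compound 1 gives 3000 nM
compound 2 `Ic1ccc(NC2=NCCO2)cc1`: compound 2 gives 2900 nM
compound 3 `CC(C)(C)c1ccc(NC(=O)NC(=O)CCl)cc1`: compound 3 gives 4800 nM

Compound 1 and compound 2 share one core and differ in a single place, (iodo in place of tert-butyl on an aromatic carbon). The step in this assay is a 1.0-fold lower number from compound 1 to compound 2 (0.01 log units; within the scatter), so the two numbers cannot be told apart by this measurement.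

Compound 3 rests on a different core. The difference between the core of compound 1 and the core of compound 3 is not broken down here. In this assay the number for compound 3 lies within the scatter of the number for compound 1, and likewise within the scatter of the number for compound 2, so no order among the three measured compounds can be drawn.

Compound 4 `O=C(CCl)NC(=O)Nc1ccc(I)cc1` is the next member and has not yet been measured in this assay. It differs from compound 3 by iodo in place of tert-butyl on an aromatic carbon. Among the measured compounds shown here, this is the same kind of change as the one from compound 1 to compound 2, but not the same: in compound 1 the exchanged group is para to a group of 6 heavy atoms, while in compound 3 it is para to a group of 8 heavy atoms. For the measured compounds named here, the one earlier instance of this change, a 1.0-fold lower number from compound 1 to compound 2 (0.01 log units; within the scatter), stayed within the scatter, and that single observation is the only basis available.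

The step from compound 3 to compound 4 is therefore expected to be small, a 1.0-fold lower number from compound 3 to compound 4 (0.02 log units; within the scatter). Compound 4 is estimated at 4600 nM in this assay, with the expected range running from 2000 nM to 10000 nM.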

Compound 4, concentration for 50% growth inhibition: 6800 nM
The estimate for compound 4 lay 1.5-fold (0.17 log units) below the measured number, within the range that was stated.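

In this assay, iodo in place of tert-butyl on an aromatic carbon gives a 1.4-fold higher number from compound 3 to compound 4 (0.15 log units; within the scatter), so on this second core too the exchange leaves the number within the scatter. Set beside the earlier instance, the two steps cannot be told apart: the same change on two cores in this assay, a 1.0-fold lower number (0.01 log units; within the scatter) from compound 1 to compound 2 and a 1.4-fold higher number (0.15 log units; within the scatter) from compound 3 to compound 4, 1.5-fold (0.17 log units) apart, within the scatter of two such steps This shows that, on these two cores and in this assay, the exchange can be carried from one core to the other with no measurable difference in its outcome; it does not show that the two groups are interchangeable on other cores, since the comparison rests on only two pairs, and a small dependence on the core could remain hidden within the scatter.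

The compounds shown carry only tert-butyl or iodo on this aromatic carbon, so it remains open whether an amine, a carboxylic acid or a longer alkyl chain there would give a number beyond the scatter of these values. It also remains open whether the flat outcome of this exchange would hold on a third core, as no pair beyond the two shown tests it.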